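Aryl swap on an aromatic nitrogen across two cores

This account rests on a few compounds, and the source may have more. Where it says the series, first, only, none or still open, it means among the compounds named here.

Compound 1 `Cc1cc(=O)n(-c2cccc(F)c2)nc1C(=O)Nc1ccc(Oc2ncnc3ccsc23)c(F)c1` gives 5220 nM in a functional assay on A549 cells (Homo sapiens) for cytotoxicity, read by MTT assay, with a stated time of 72 h; a lower number here means a stronger inhibitor, a higher number a weaker inhibitor. Compound 2 `Cc1ccc(-n2nc(C(=O)Nc3ccc(Oc4ncnc5ccsc45)c(F)c3)c(C)cc2=O)cc1` gives 5890 nM in this assay; the change is 4-methylphenyl in place of 3-fluorophenyl on an aromatic nitrogen and the step is a 1.1-fold higher number from compound 1 to compound 2 (0.05 log units; within the scatter). Compound 3 `Cc1cc(=O)n(-c2cccc(F)c2)nc1C(=O)Nc1ccc(Oc2ncnc3sccc23)c(F)c1` gives 19500 nM in this assay and stands as the highest number of the three; its step from compound 1 is a 3.7-fold higher number from compound 1 to compound 3 (0.57 log units; beyond the scatter), the two differing by a group of 9 heavy atoms (6 carbon, 2 nitrogen, 1 sulfur; one five-membered aromatic ring with 1 hetero atom, one six-membered aromatic ring with 2 hetero atoms) in place of a group of 9 heavy atoms (6 carbon, 2 nitrogen, 1 sulfur; one five-membered aromatic ring with 1 hetero atom, one six-membered aromatic ring with 2 hetero atoms), on an oxygen on an aromatic ring, the same atoms joined differently. Compound 4 `Cc1ccc(-n2nc(C(=O)Nc3ccc(Oc4ncnc5sccc45)c(F)c3)c(C)cc2=O)cc1` is not yet measured. It differs from compound 3 by 4-methylphenyl in place of 3-fluorophenyl on an aromatic nitrogen, the same change made from compound 1 to compound 2, since the two place descriptions agree word for word. Among the measured compounds shown here, on the core of compound 1 that change gave a 1.1-fold higher number from compound 1 to compound 2 (0.05 log units; within the scatter), a step within the scatter; carried onto the core of compound 3 it is expected to behave alike, with only one prior instance to rest on. The expected step is a 1.1-fold higher number from compound 3 to compound 4 (0.03 log units; within the scatter), essentially flat. Compound 4 is therefore estimated at 21000 nM, with a likely range from 9000 nM to 48000 nM, in this assay.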

Compound 4, half-maximal inhibitory concentration: > 40000 nM
Compound 4 ended at the assay's limit (the forecaster's own chance of this, stated with the estimate: 15%); at least 1.9-fold (0.27 log units) between middle value and limit.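

In this assay compound 4 gives > 40000 nM, which is a limit of the assay: the limit of > 40000 nM in this assay, at which 1 of the 4 values shown sits. The change to 4-methylphenyl from 3-fluorophenyl reads as an at least 2.0-fold higher number from compound 3 to compound 4 (0.31 log units; beyond the scatter), a step beyond the scatter, so the flat result on the core of compound 1 cannot be assumed to carry over to the core of compound 3, yet no real difference between the two cores is established: the same change on two cores in this assay, a 1.1-fold higher number (0.05 log units; within the scatter) from compound 1 to compound 2 and an at least 2.0-fold higher number (0.31 log units; beyond the scatter) from compound 3 to compound 4; the limit leaves it open whether they differ. The core exchange reads as an at least 6.7-fold higher number from compound 2 to compound 4 (0.83 log units; beyond the scatter), and the core of compound 3 gives the higher number with both aryl groups, though whether the size of that exchange depends on the aryl group remains unsettled: the same change on two cores in this assay, a 3.7-fold higher number (0.57 log units; beyond the scatter) from compound 1 to compound 3 and an at least 6.7-fold higher number (0.83 log units; beyond the scatter) from compound 2 to compound 4; the limit leaves it open whether they differ.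

Transfer of the change between cores rests on only two pairs, one of them ending at the limit. Going by these compounds, how a chlorophenyl, a methoxyphenyl or an amine-bearing aryl group on the aromatic nitrogen would read on either core remains open.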